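This account rests on a few compounds, and the source may have more. Where it says the series, first, only, none or still open, it means among the compounds named here.

Measured so far:
In a functional assay on Bel-7402 cells (Homo sapiens) for cytotoxicity, read by MTT assay (on this read-out lower numbers stand for stronger inhibition and higher numbers for weaker inhibition), compound 1 `COc1cccc(/C=C/C(=O)c2sc(Nc3ccccc3)nc2C)c1` gives only a limit, > 25000 nM.
In this assay compound 2 `COc1cccc(/C=C/C(=O)c2sc(Nc3ccc(C)cc3)nc2C)c1` gives only a limit, > 25000 nM.

Compound 2 therefore stands on no number but on a limit, and both measured values sit on the same one (the limit of > 25000 nM in this assay, at which 2 of the 2 values shown sit). Within the data shown here, the single measured step, a step that the two limits leave unreadable from compound 1 to compound 2, cannot be read in size or direction. Compound 3 `COc1cccc(/C=C/C(=O)c2sc(Nc3ccc(Cl)c(Cl)c3)nc2C)c1` differs from compound 2 by 3,4-dichlorophenyl in place of 4-methylphenyl on a nitrogen on an aromatic ring. With no readable step to rest on, no direction is expected for a step that the limit leaves unreadable from compound 2 to compound 3; compound 3 is expected to come out again as a limit or near it, at an estimated 30000 nM with a range from 8000 nM to 100000 nM.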

Compound 3, half-maximal inhibitory concentration: > 25000 nM
Compound 3: a limit, no number (the forecaster's own chance of this, stated with the estimate: 70%); the middle value does not contradict the limit.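

Compound 1, compound 2 and compound 3 all give only a limit, so no step among them can be read in size or direction: the limit of > 25000 nM in this assay, at which 3 of the 3 values shown sit.

Still open, going by these compounds, is whether changing the group on the nitrogen alters the result in this assay at all.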